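The source may hold more compounds than are shown below. What is called first, only, known or untested is meant among the compounds shown, and "the series" means these compounds.

Measured compounds:
Compound 1, `COc1ccc(C(/C=C/c2cccs2)=N/O)cc1`: 8490 nM
Compound 2, `O/N=C(\C=C\c1cccs1)c1ccc(Br)cc1`: 11200 nM
Compound 3, `Cc1ccc(C(/C=C/c2ccc(Br)cc2)=N/O)cc1`: 11600 nM

Of the compounds shown here, three have been measured in a functional assay (Mus musculus, strain Balb/c) for inhibition, read by ELISA, with a stated time of 72 h; a lower number here means a stronger inhibitor, a higher number a weaker inhibitor. Compound 1 gives 8490 nM, compound 2 gives 11200 nM, and compound 3 gives 11600 nM. All three numbers lie within the scatter of one another, so no order among them can be drawn from these data.

From compound 2 to compound 1 the change is methoxy in place of bromo on an aromatic carbon; this change brought a 1.3-fold lower number from compound 2 to compound 1 (0.12 log units; within the scatter). Compound 3 and compound 2 differ in their cores, and that difference is not broken down here; their two values show no more than that they sit close together.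

Compound 4, `COc1ccc(/C=C/C(=N\O)c2ccc(C)cc2)cc1`, has not yet been measured. Among the measured compounds shown here, it differs from compound 3 by methoxy in place of bromo on an aromatic carbon, which is the same change as the one from compound 2 to compound 1. Because the earlier step was a 1.3-fold lower number from compound 2 to compound 1 (0.12 log units; within the scatter), a step of similar, small size is expected here, a 1.3-fold lower number from compound 3 to compound 4 (0.11 log units; within the scatter). Compound 4 is therefore expected to give about 9000 nM in this assay, with an expected range from 4000 nM to 20000 nM.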

Compound 4, half-maximal inhibitory concentration: 6240 nM
The estimate for compound 4 lay 1.4-fold (0.16 log units) above the measured number, within the range that was stated.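

In this assay, methoxy in place of bromo on an aromatic carbon gave a 1.9-fold lower number from compound 3 to compound 4 (0.27 log units; within the scatter). Set beside the earlier step, the change reads alike on the two cores: the same change on two cores in this assay, a 1.3-fold lower number (0.12 log units; within the scatter) from compound 2 to compound 1 and a 1.9-fold lower number (0.27 log units; within the scatter) from compound 3 to compound 4, 1.4-fold (0.15 log units) apart, within the scatter of two such steps. The two steps therefore cannot be told apart, and the change carried from one core to the other with no detectable difference, but neither step on its own lies beyond the scatter, so the data do not show that the change has any real effect in this assay, and two cores are too few to support a rule for the whole series.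

The compounds shown leave open whether a group of another kind at this place, such as an amine, a carboxylic acid or a longer chain, would give a step beyond the scatter. They also leave open whether methoxy in place of bromo would read the same way on any core other than these two.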